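This account rests on a few compounds, and the source may have more. Where it says the series, first, only, none or still open, it means among the compounds named here.

Three compounds in this series have been run through a functional assay on HL-60 cells (Homo sapiens) for inhibition, read by CCK-8 assay, with a stated time of 48 h, tested at 20 uM; a higher number here means more inhibition of growth at the concentration tested, a lower number less inhibition of growth. Compound 1, with the structure `COc1ccc(Cc2nnc(NC(=O)/C(C#N)=C/c3ccccc3OS(=O)(=O)c3ccc(C)cc3)s2)cc1`, gives 25%. Compound 2, with the structure `COc1ccc(Cc2nnc(NC(=O)/C(C#N)=C/c3ccccc3OS(=O)(=O)c3ccc(OC)cc3)s2)cc1`, gives 100%. Compound 3, with the structure `Cc1ccc(S(=O)(=O)Oc2ccccc2/C=C(\C#N)C(=O)Nc2nnc(Cc3ccccc3)s2)cc1`, gives 16%, the lowest of the three, although its gap to compound 1 is within the scatter.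

The change from compound 1 to compound 2 is methoxy in place of methyl on an aromatic carbon, and it made a large step: a number 75 percentage points higher from compound 1 to compound 2 (beyond the scatter). The core of compound 3 differs from the core of compound 1 by hydrogen in place of methoxy on an aromatic carbon, which moved the number only a little: a number 9 percentage points lower from compound 1 to compound 3 (within the scatter).

Compound 4, with the structure `COc1ccc(S(=O)(=O)Oc2ccccc2/C=C(\C#N)C(=O)Nc2nnc(Cc3ccccc3)s2)cc1`, has not yet been measured in this assay. It differs from compound 3 by methoxy in place of methyl on an aromatic carbon. This is the same change as that from compound 1 to compound 2, made on the same place in the same words, only on a core lacking the methoxy on the benzyl group. Because the step of a number 75 percentage points higher from compound 1 to compound 2 (beyond the scatter) was so large, a large upward step is expected from compound 3 to compound 4 as well, roughly a number 59 percentage points higher from compound 3 to compound 4 (beyond the scatter), although the read-out cannot rise past complete inhibition of growth and a single earlier step is a thin basis. Compound 4 is therefore estimated to give 75%, with a plausible range from 35% to 100%.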

Compound 4, percent growth inhibition at one concentration: 100%
The estimate for compound 4 lay 25 percentage points below the measured number; the measured number falls inside the stated range.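

In this assay, exchanging the 4-methylphenyl for the 4-methoxyphenyl on the sulfonyl group again gave a large rise, a number 84 percentage points higher from compound 3 to compound 4 (beyond the scatter), and this step agrees with the one on the other core: the same change on two cores in this assay, a number 75 percentage points higher (beyond the scatter) from compound 1 to compound 2 and a number 84 percentage points higher (beyond the scatter) from compound 3 to compound 4, 9 percentage points apart, within the scatter of two such steps. The other change, hydrogen in place of methoxy on the benzyl group, left the result where it stood, no change at the digits printed from compound 2 to compound 4 (within the scatter), and it too looks the same on both cores: the same change on two cores in this assay, a number 9 percentage points lower (within the scatter) from compound 1 to compound 3 and no change at the digits printed (within the scatter) from compound 2 to compound 4, 9 percentage points apart, within the scatter of two such steps. As far as these compounds go, compound 2 gives 100% and compound 4 gives 100%, which is complete inhibition of growth, so the full size of the rise on each core remains unknown, and two cores this close to each other do not show that the change would carry to a core that differs more.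

The compounds shown hold only methyl or methoxy in this place, which leaves open what an ethoxy group, a chlorine atom or an amine would do there. With a single test concentration and both methoxy compounds at the top of the scale, they also leave open whether compound 2 and compound 4 would separate at lower concentrations.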